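The compounds below may be only part of what the source reports. "The series", "measured", "known", "first", "only" and "open" are said of these compounds alone.

Compound 1, `CCCCCCCCCCCCCCc1nc(OC2CCC2)nc(N2CCC2)c1O`, gives 54% in a functional assay on cells (Lymphocyte, Homo sapiens), read by a luciferase reporter and ATP content, with a stated time of 48 h, tested at 20 uM; on this read-out higher numbers stand for a weaker effect at the one concentration tested and lower numbers for a stronger effect. Compound 2, `CCCCCCCCCCCCCCCCc1nc(OC2CCC2)nc(N2CCC2)c1O`, carries ethyl in place of hydrogen on a saturated chain carbon, ten or more bonds along the chain from an aromatic carbon and gives 99% in this assay, so the step of a number 45 percentage points higher from compound 1 to compound 2 (beyond the scatter). Compound 3, `CCCCCCCCCCCCCCc1nc(OC2CCC2)nc(OC2CCC2)c1O`, gives 94% in this assay, and the step of a number 40 percentage points higher from compound 1 to compound 3 (beyond the scatter). The values of compound 2 and compound 3 lie within the scatter of each other, so nothing separates them.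

Compound 4, `CCCCCCCCCCCCCCCCc1nc(OC2CCC2)nc(OC2CCC2)c1O`, has not yet been measured in this assay. It differs from compound 3 by ethyl in place of hydrogen on a saturated chain carbon, ten or more bonds along the chain from an aromatic carbon; the same change was made from compound 1 to compound 2, where it gave a large step. The two cores on which this change is made differ by cyclobutyloxy in place of azetidin-1-yl on an aromatic carbon. The place of the change is described in the same words in both pairs, so the change from compound 3 to compound 4 is the same change as that from compound 1 to compound 2.

Within the data shown here, because compound 3 already stands at 94%, a step as large as the one from compound 1 to compound 2 cannot repeat; the read-out has little room left. The step from compound 3 to compound 4 in this assay is therefore expected to be a number 4 percentage points higher from compound 3 to compound 4 (within the scatter), within the scatter. For compound 4 in this assay the estimate is 98%, expected to fall between 88% and 104%.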

Compound 4, a percentage reported as activity, at one concentration (the size of the read-out at that concentration, not a potency): 96%
Estimate against measurement, compound 4: 2 percentage points above; measured number inside the range.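

In this assay, ethyl in place of hydrogen on a saturated chain carbon, ten or more bonds along the chain from an aromatic carbon, gave a number 2 percentage points higher from compound 3 to compound 4 (within the scatter), so the large step seen on the core of compound 1 did not carry over to the core of compound 3: the same change on two cores in this assay, a number 45 percentage points higher (beyond the scatter) from compound 1 to compound 2 and a number 2 percentage points higher (within the scatter) from compound 3 to compound 4, 43 percentage points apart, beyond the scatter of two such steps

Cyclobutyloxy in place of azetidin-1-yl on an aromatic carbon behaved the same way, giving a number 3 percentage points lower from compound 2 to compound 4 (within the scatter), so its large step on the shorter chain did not carry over to the longer one: the same change on two cores in this assay, a number 40 percentage points higher (beyond the scatter) from compound 1 to compound 3 and a number 3 percentage points lower (within the scatter) from compound 2 to compound 4, 43 percentage points apart, beyond the scatter of two such steps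

Within these four compounds, therefore, the size of each change depends on what stands at the other place, but the data do not show why, and this single square of compounds cannot tell whether the same would hold on any other core.

The compounds shown leave open how the read-out would respond on the core of compound 1 to a shorter chain or to a chain ending in a carboxylic acid. They also leave open whether a pyrrolidin-1-yl group or an open-chain amine on that aromatic carbon would follow azetidin-1-yl or cyclobutyloxy.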